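The source may hold more compounds than are shown below. What is called first, only, known or untested is meant among the compounds shown, and "the series" means these compounds.

Compound 1, `NNC(=O)Cc1cc(=O)oc2cc(OCc3cccc(Cl)c3)ccc12`, gives 2500 nM in an assay (strain Wistar) for inhibition of Amine oxidase [flavin-containing] A (Rattus norvegicus); a higher number here means a weaker inhibitor, a lower number a stronger inhibitor.
Compound 2, `NC(=O)Cc1cc(=O)oc2cc(OCc3cccc(Cl)c3)ccc12`, gives 26000 nM in this assay.
Compound 3, `O=C(Cc1cc(=O)oc2cc(OCc3cccc(Cl)c3)ccc12)NCc1ccccc1`, reaches only the limit of the assay, > 100000 nM, in this assay.

Compound 3 therefore stands at the weak end of what has been measured: its value is a limit, not a number, and the limit of > 100000 nM in this assay, at which 1 of the 3 values shown sits, is the only thing that can be said of it. The two changes that reach it from the other compounds were both large: an at least 40-fold higher number from compound 1 to compound 3 (1.60 log units; beyond the scatter) and an at least 3.8-fold higher number from compound 2 to compound 3 (0.58 log units; beyond the scatter). Both kept the amide-type nitrogen and changed what sits on it; both pushed toward weaker inhibition.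

Compound 4, `CN(Cc1ccccc1)Cc1cc(=O)oc2cc(OCc3cccc(Cl)c3)ccc12`, goes one step further. The change is benzyl(methyl)amino in place of benzylcarbamoyl on a saturated chain carbon bound to an aromatic carbon. Among the compounds with values here, no measured step tests this kind of exchange, so only the direction of the earlier steps can guide an expectation: every change away from compound 1 so far has weakened binding, and compound 3 already lies at the limit. Compound 4 is therefore expected to remain weak, with a value near the limit and a fair chance that again only a limit is reported. The estimate for compound 4 in this assay is 60000 nM, between 10000 nM and 300000 nM, which would mean a step of an at least 1.6-fold lower number from compound 3 to compound 4 (0.22 log units; that floor lies within the scatter).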

Compound 4, half-maximal inhibitory concentration: > 100000 nM
Compound 4: a limit, no number; the forecaster's own chance of this, stated with the estimate: 50%; middle value at least 1.6-fold (0.22 log units) from the limit.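

Until now, only the substituent on the amide-type nitrogen had changed, whereas compound 4 replaces the whole benzylcarbamoyl group on the saturated chain carbon bound to an aromatic carbon, and benzyl(methyl)amino, which has no hydrogen-bond donor, still gives no measurable number in this assay. Compared with the two compounds that do give numbers, there is an at least 3.8-fold higher number from compound 2 to compound 4 (0.58 log units; beyond the scatter), and there is also an at least 40-fold higher number from compound 1 to compound 4 (1.60 log units; beyond the scatter). Compound 3 and compound 4 both give a limit rather than a number, so the step between them cannot be read and the benzylcarbamoyl and benzyl(methyl)amino groups cannot be ranked against each other, as the evidence shows: the limit of > 100000 nM in this assay, at which 2 of the 4 values shown sit.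

Going by these compounds, it remains open whether a smaller group at this place, such as a plain amine or dimethylamino, would bring the value back into the measurable range, or whether the benzyl ring is what keeps both compounds at the limit. A carboxylic acid or a longer chain ending in aminocarbamoyl would also test whether the better result of compound 1 depends on that group alone.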